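Swapping a Fluorophenyl for Pyridyl on a Shared Core

The source may hold more compounds than are shown below. What is called first, only, known or untested is meant among the compounds shown, and "the series" means these compounds.

Three measured compounds share one core and differ at the amide side. Compound 1 `Nc1nc(N2CCN(C(=O)COc3ccc(Cl)cc3)CC2)c2nc(-c3ccc(F)cc3)sc2n1` gives 490 nM in a functional assay on cells (Lymphocyte, Homo sapiens); on this read-out higher numbers stand for weaker inhibition and lower numbers for stronger inhibition. Compound 2 `Cc1cccc(NC(=O)N2CCN(c3nc(N)nc4sc(-c5ccc(F)cc5)nc34)CC2)c1` gives 300 nM, and compound 3 `Nc1nc(N2CCN(C(=O)COc3ccc(Br)cc3)CC2)c2nc(-c3ccc(F)cc3)sc2n1` gives 380 nM. Compound 1 carries the highest of the three numbers, but the steps of a 1.6-fold lower number from compound 1 to compound 2 (0.21 log units; within the scatter) and a 1.3-fold lower number from compound 1 to compound 3 (0.11 log units; within the scatter) both lie within the scatter, as does the step of a 1.3-fold higher number from compound 2 to compound 3 (0.10 log units; within the scatter), so the three compounds cannot be told apart on these data.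

Compound 4 `Nc1nc(N2CCN(C(=O)COc3ccc(Cl)cc3)CC2)c2nc(-c3ccncc3)sc2n1` changes a different part of the molecule: pyridin-4-yl in place of 4-fluorophenyl on an aromatic carbon. The change sits on an aromatic carbon of a five-membered aromatic ring with one nitrogen and one sulfur, part of a fused system of two rings. Among the compounds with values here, no measured step touches this position; all three measured steps concern the amide side and were within the scatter. There is therefore no measured guide for this change, and the estimate rests on the value of compound 1 with a wide range. Compound 4 is expected to give about 700 nM, between 200 nM and 2500 nM. This estimate means an expected step of a 1.4-fold higher number from compound 1 to compound 4 (0.15 log units; within the scatter).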

Compound 4, half-maximal inhibitory concentration: 40 nM
Estimate against measurement, compound 4: 18-fold (1.24 log units) above; measured number below the stated range.
By their numbers in this assay, from the lowest: compound 4; then compounds 2, 3 and 1 (each within the scatter of the next).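

Among compounds 1, 2 and 3, changes on the amide side stayed within the scatter, but this position on the other side of the molecule clearly matters in this assay. On an aromatic carbon of the five-membered aromatic ring with one nitrogen and one sulfur, pyridin-4-yl in place of 4-fluorophenyl gives a large step (a 12-fold lower number from compound 1 to compound 4 (1.09 log units; beyond the scatter)), which means stronger inhibition. This swap removes the fluorine and brings in a ring nitrogen, counted as one hydrogen-bond acceptor, and because both differences arrive together, this single pair cannot separate them.

The compounds shown leave open whether a plain phenyl or a pyridin-3-yl here would behave like pyridin-4-yl, and whether the step would recur with the (3-methylphenyl)amino group of compound 2. Nothing available here explains the size of this step.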